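Compound 3: acetamido in place of ring hydrogen

The source may hold more compounds than are shown below. What is called first, only, known or untested is meant among the compounds shown, and "the series" means these compounds.

Compound 1 `Cc1cc(C(=O)O)nn1Cc1cc(Br)ccc1OCc1ccccc1` and compound 2 `O=C(O)c1ccn(Cc2cc(Br)ccc2OCc2ccccc2)n1` share one core. In a functional assay on CHO-K1 cells for antagonist activity at prostaglandin E2 receptor EP1 subtype (Homo sapiens), read by FLIPR (on this read-out higher numbers stand for weaker inhibition and lower numbers for stronger inhibition), compound 1 gives 15.1 nM and compound 2 gives 55 nM, the highest of the two numbers, the step being a 3.6-fold higher number from compound 1 to compound 2 (0.56 log units; beyond the scatter). Compound 3 `CC(=O)Nc1cc(C(=O)O)nn1Cc1cc(Br)ccc1OCc1ccccc1` differs from compound 2 by acetamido in place of hydrogen on an aromatic carbon. Only the step from compound 1 to compound 2 bears on this position, and it shows a modest shift; whether acetamido acts like methyl there is not shown. The expected step is a 1.4-fold lower number from compound 2 to compound 3 (0.14 log units; within the scatter), modest at most. Compound 3 is therefore estimated at 40 nM, range 8 nM to 200 nM.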

Compound 3, inhibition constant: < 2000 nM
Compound 3: a limit, no number (the forecaster's own chance of this, stated with the estimate: 5%); the middle value lies beyond the limit too.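

In this assay compound 3 gives < 2000 nM, a limit and not a number, so the steps to it from compound 1 and compound 2 cannot be read. Going by these compounds, how acetamido compares with hydrogen or methyl at this position remains open.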